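A few compounds are considered here, and "the series" means these few. Any claim that something is new, unique, unknown or untested is made for them only; others in the source may bear on it.

In a functional assay on HCT-116 cells (Homo sapiens) for cytotoxicity, read by sulforhodamine B assay, with a stated time of 48 h (on this read-out lower numbers stand for stronger inhibition and higher numbers for weaker inhibition), compound 1 (`COc1cc(/C=C/C(=O)/C=C/c2cc(OC)c(OC)c(OC)c2)ccc1OCc1cn(CCOc2cc(=O)oc3ccccc23)nn1`) gives 2210 nM and so holds the lower of the two numbers measured. Compound 2 (`COc1cc(/C=C/C(=O)/C=C/c2cc(OC)c(OC)c(OC)c2)ccc1OCc1cn(CCCOc2cc(=O)oc3ccccc23)nn1`) gives 8650 nM as the higher number, a gap beyond the usual scatter. Compound 3 (`COc1ccc(/C=C/C(=O)/C=C/c2ccc(OCc3cn(CCOc4cc(=O)oc5ccccc45)nn3)c(OC)c2)cc1`) differs from compound 1 in one place (4-methoxyphenyl in place of 3,4,5-trimethoxyphenyl on a double-bonded chain carbon bound to a double-bonded chain carbon), with 4-methoxyphenyl in place of 3,4,5-trimethoxyphenyl on a double-bonded chain carbon bound to a double-bonded chain carbon. Among the measured compounds shown here, no measured pair of compounds shows this change, so the data give no direct guide to its size. In this assay a moderate move toward weaker inhibition is expected, and a 2.0-fold higher number from compound 1 to compound 3 (0.31 log units; beyond the scatter) is the estimated step, although a step within the scatter cannot be ruled out. Compound 3 is expected at 4500 nM in this estimate, with an expected range of 1500 nM to 13500 nM on repeated measurement.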

Compound 3, half-maximal inhibitory concentration: 9290 nM
Compound 3: middle estimate off by 2.1-fold (0.31 log units), on the low side, within the range that was stated.
By their numbers in this assay, from the lowest: compound 1; then compounds 2 and 3 (each within the scatter of the next).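

In this assay, among the compounds shown here, the move from 3,4,5-trimethoxyphenyl to 4-methoxyphenyl on a double-bonded chain carbon bound to a double-bonded chain carbon gives a 4.2-fold higher number from compound 1 to compound 3 (0.62 log units; beyond the scatter) and is the first change at this place to be measured. It shows that this position affects the result: with the rest of compound 1 held constant, the smaller 4-methoxyphenyl group goes with weaker inhibition. Nothing available explains this step.

Going by these compounds, with only these two aryl groups compared, it remains open whether an intermediate group such as 3,4-dimethoxyphenyl would fall between them, or how an unsubstituted phenyl or a 4-aminophenyl group would behave. On these data alone, it is also open whether the same change would give a step of similar size on the longer chain of compound 2.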